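The compounds below may be only part of what the source reports. "The series", "measured", "known", "first", "only" and "open" are said of these compounds alone.

Compound 2 `CCn1c(SCC(=O)Nc2ccc(/C(C)=N/O)cc2)nnc1-c1ccc(OC)c(OC)c1` stands highest of the three measured compounds: in a functional assay on the whole organism (strain albino) for inhibition, with Rattus norvegicus as the target, read by paw edema, with stated times of 30 min and 5 h, at a dose of 0.28 mmol/kg by the oral route (on this read-out lower numbers stand for less inhibition and higher numbers for more inhibition at the one dose given (going by the name of the read-out)), compound 2 gives 73%. Compound 1 `C/C(=N\O)c1ccc(NC(=O)CSc2nnc(-c3ccccc3)n2-c2ccccc2)cc1` gives 66% and compound 3 `CCn1c(SCC(=O)Nc2ccc(C(C)=O)cc2)nnc1-c1ccc(OC)c(OC)c1` gives 66%, both within the scatter of compound 2. Going by the values given here, the one single-point step among them, a number 7 percentage points lower from compound 2 to compound 3 (within the scatter), changed nothing beyond the scatter. Compound 4 `COc1ccc(-c2nnc(SCC(=O)Nc3ccc(/C(C)=N/O)cc3)n2-c2ccccc2)cc1OC` differs from compound 2 by phenyl in place of ethyl on an aromatic nitrogen. Among the compounds with values here, no measured step bears on this change: compound 1 also carries a phenyl on the ring nitrogen, but differs from compound 2 in two places, so its value only shows that such a compound also sits within the scatter of compound 2. Compound 4 is therefore expected to show a number 5 percentage points lower from compound 2 to compound 4 (within the scatter), with an estimate of 68% and a range from 55% to 80%.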

Compound 4, a percentage reported as inhibition, in the whole organism at one dose (the size of the read-out at that dose, not a potency): 76%
Estimate against measurement, compound 4: 8 percentage points below; the range from low to high includes it.
By their numbers in this assay, from the lowest: compounds 1, 3, 2 and 4 (each within the scatter of the next).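

In this assay, phenyl in place of ethyl on the aromatic nitrogen gives a number 3 percentage points higher from compound 2 to compound 4 (within the scatter) and thus shows directly that this position carries a six-membered aromatic ring without a change beyond the scatter. On the aromatic carbon, 3,4-dimethoxyphenyl in place of phenyl gives a number 10 percentage points higher from compound 1 to compound 4 (within the scatter) and so also leaves the read-out within the scatter. Nothing available accounts for either step. Still open, as far as these compounds go, is whether a longer chain, such as butyl, or a benzyl group on this ring nitrogen would stay within the scatter. Also open, from the compounds shown here alone, is whether an amine or a carboxylic acid in place of the methoxy groups would do so.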